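The source may report more compounds than this note shows. Statements on the series, on what has been measured and on what is new or still open speak of the compounds shown alone.

Series of amides built on the shared core of compound 2 `CN(C)CCC(NC(=O)c1ccccc1)c1ccc(Cl)cc1`, which in an assay on NIH3T3 cells with Urotensin-2 receptor (Homo sapiens) as the target (a higher number here means a larger maximal response, a lower number a smaller maximal response), gives 158%, the higher of the two numbers so far. Going by the values given here, compound 1 `Cc1c(Cl)cccc1C(=O)NC(CCN(C)C)c1ccc(Cl)cc1`, the only other measured member, gives 142%; the step of a number 16 percentage points higher from compound 1 to compound 2 (beyond the scatter) is the sole change at the same carbonyl carbon and is the one that bears here. Compound 3 `Cc1ccccc1NC(=O)NC(CCN(C)C)c1ccc(Cl)cc1` differs from compound 2 by (2-methylphenyl)amino in place of phenyl on a carbonyl carbon. Among the compounds with values here, no measured step covers this change, so a step within scatter or a modest drop is expected, a number 13 percentage points lower from compound 2 to compound 3 (beyond the scatter). Compound 3 is therefore estimated at 145%, range 110% to 175%.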

Compound 3, largest response reached (reported as efficacy), in percent of the reference or control that the assay uses: 175%
Beside the measured number, compound 3's estimate is 30 percentage points below it; the measured number falls inside the stated range.
By their numbers in this assay, from the lowest: compound 1; then compound 2; then compound 3.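

In this assay the place on the carbonyl carbon accepts (2-methylphenyl)amino, with its hydrogen-bond donor, and the maximal response goes up rather than down: a number 17 percentage points higher from compound 2 to compound 3 (beyond the scatter). Going by these compounds alone, the change from the 3-chloro-2-methylphenyl compound gives the only step so far printed as large: a number 33 percentage points higher from compound 1 to compound 3 (beyond the scatter). No evidence bears on the reason for this rise.

As far as these compounds go, whether the rise follows the nitrogen or the methyl stays open, and plain phenylamino on the same carbonyl carbon would separate the two. From the compounds shown here alone, whether the aromatic ring is needed also stays open, a question cyclohexylamino would address.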